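Swapping the side chain of compound 2

The source may hold more compounds than are shown below. What is called first, only, known or untested is meant among the compounds shown, and "the series" means these compounds.

Values in an ADME assay on HEK293 cells (Homo sapiens) for cytotoxicity, read by CCK-8 assay, with a stated time of 48 h; a lower number here means a stronger inhibitor, a higher number a weaker inhibitor:
- compound 1 `COc1ccc(/C=C\c2cc(OC)c(OC)c(OC)c2)cc1OCc1ccc(CN2CCCCC2C(=O)O)cc1`: > 50000 nM
- compound 2 `COc1ccc(/C=C\c2cc(OC)c(OC)c(OC)c2)cc1OCc1ccc(CNCCN(C)C)cc1`: 39000 nM

Compound 1 has no true number, because > 50000 nM is a limit of the assay. Going by the values given here, compound 2 gives 39000 nM, the only true number so far. Compound 3 `COc1ccc(/C=C\c2cc(OC)c(OC)c(OC)c2)cc1OCc1ccc(CN2CC[C@@H](O)C2)cc1` keeps the core of compound 2 and changes one group on a saturated chain carbon bound to an aromatic carbon: 3-hydroxypyrrolidin-1-yl in place of (2-(dimethylamino)ethyl)amino on a saturated chain carbon bound to an aromatic carbon. Among the compounds with values here, one measured step bears on this, at the same place: an at least 1.2-fold lower number from compound 1 to compound 2 (0.10 log units; that floor lies within the scatter). That step is small and its size is only a floor, so it offers weak guidance. No step beyond the scatter is therefore expected in this assay, and a reading that gives only a limit is also possible. The expected step is a 1.2-fold higher number from compound 2 to compound 3 (0.06 log units; within the scatter). For compound 3 the estimated value is 45000 nM, with an expected range of 20000 nM to 90000 nM.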

Compound 3, half-maximal inhibitory concentration: > 50000 nM
Compound 3: no number, only a limit; the forecaster's own chance of this, stated with the estimate: 45%; middle value at least 1.1-fold (0.04 log units) away from the limit.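

In this assay, 3-hydroxypyrrolidin-1-yl in place of (2-(dimethylamino)ethyl)amino on a saturated chain carbon bound to an aromatic carbon gives an at least 1.2-fold higher number from compound 2 to compound 3 (0.10 log units; that floor lies within the scatter), so this change cannot be told apart from ordinary scatter. Going by these compounds alone, a second, quite different group at this place now also ends at a limit of the assay rather than a number, which leaves compound 2 as the only compound with a true number: the limit of > 50000 nM in this assay, at which 2 of the 3 values shown sit. The step between compound 1 and compound 3 cannot be read, as both values are limits.

As far as these compounds go, how far compound 1 and compound 3 lie past that limit stays unknown. Also open, from the compounds shown here alone, is whether a morpholin-4-yl group or an amine on a longer chain at this carbon would give a clearly lower number than compound 2.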